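A few compounds are considered here, and "the series" means these few. Any claim that something is new, unique, unknown or untested is made for them only; others in the source may bear on it.

Measured so far:
- compound 1, `CN(C)C(=O)c1cc2cnc(Nc3ccc(S(=O)(=O)NCCCCN=C=S)cc3)nc2n1C1CCCC1`: 39.4%
- compound 2, `CN(C)C(=O)c1cc2cnc(Nc3ccc(C(=O)NCCCN=C=S)cc3)nc2n1C1CCCC1`: 32.9%
- compound 3, `CN(C)C(=O)c1cc2cnc(Nc3ccc(C(=O)NCCCCCCN=C=S)cc3)nc2n1C1CCCC1`: 35.8%

In a functional assay on A549 cells (Homo sapiens) for inhibition, read by CCK-8 assay, with a stated time of 72 h, tested at 1 uM (on this read-out higher numbers stand for a stronger effect at the one concentration tested and lower numbers for a weaker effect), compound 2 gives the lowest of the three numbers, yet both steps that involve it (a number 2.9 percentage points higher from compound 2 to compound 3 (within the scatter) and a number 6.5 percentage points lower from compound 1 to compound 2 (within the scatter)) stay within the scatter, so the three compounds cannot be told apart on these data.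

Compound 4, `CN(C)C(=O)c1cc2cnc(Nc3ccc(C(=O)NCCCN=C=S)cc3O)nc2n1C1CCCC1`, differs from compound 2 by hydroxy in place of hydrogen on an aromatic carbon. For the measured compounds named here, none of the measured steps touches the aromatic ring at all: a number 6.5 percentage points lower from compound 1 to compound 2 (within the scatter) and a number 3.6 percentage points lower from compound 1 to compound 3 (within the scatter) swap the whole side chain, and a number 2.9 percentage points higher from compound 2 to compound 3 (within the scatter) lengthens the chain. Every one of those changes was larger than the addition of a single hydroxy, and every one stayed within the scatter. There is therefore no measured precedent for this change, and no reason from the data to expect a step beyond the scatter.

Compound 4 is expected to give about 34%, in the range 20% to 50%, which corresponds to an estimated step of a number 1.1 percentage points higher from compound 2 to compound 4 (within the scatter).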

Compound 4, a percentage reported as inhibition, at one concentration (the size of the read-out at that concentration, not a potency): 55.9%
Compound 4: middle estimate off by 21.9 percentage points, on the low side; the measured number lies above the stated range.
By their numbers in this assay, from the lowest: compounds 2, 3 and 1 (each within the scatter of the next); then compound 4.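

In this assay, for the compounds shown here, hydroxy in place of hydrogen gives a number 23 percentage points higher from compound 2 to compound 4 (beyond the scatter), and unlike every step among the earlier compounds, this one lies beyond the scatter. Those earlier steps all changed the side chain, whereas this one leaves the side chain alone and adds one oxygen atom to the aromatic carbon ortho to a large group. This position on the ring can therefore change the read-out even though the much larger side-chain changes could not be told apart, but nothing shown here explains the gain.

On these data alone, it remains open whether hydroxy is special at this carbon or whether a methoxy group, an amine or a fluorine atom there would do the same. As far as these compounds go, it is also open whether hydroxy would give a similar step on the longer chain of compound 3.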